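The source may report more compounds than this note shows. Statements on the series, on what has been measured and on what is new or still open speak of the compounds shown alone.

The study concerns cytotoxicity in a toxicity assay on NIH3T3 cells (Mus musculus) for cytotoxicity, read by resazurin assay; a higher number here means that more compound is needed for the effect, a lower number that less compound is needed. Compound 1, `COc1ccc(NCc2cncn2Cc2ccc(-c3ccccc3)cc2N)cc1-c1ccccc1`, was tested there. In this assay compound 1 gives only a limit, > 1000 nM, not a number. Compound 2, `c1ccc(-c2ccc(Cn3cncc3CNc3ccc(-c4ccccc4)c(-c4ccccc4)c3)cc2)cc1`, was tested as well. In this assay compound 2 likewise gives only a limit, > 10000 nM. Compound 2 thus stands at the limit of > 10000 nM in this assay, at which 1 of the 2 values shown sits. Compound 1 stands at the limit of > 1000 nM in this assay, at which 1 of the 2 values shown sits. The unmeasured compound 3 is `c1ccc(-c2ccc(Cn3cncc3CNc3ccc(N4CCCC4)c(-c4ccccc4)c3)cc2)cc1`. It differs from compound 2 in one place: pyrrolidin-1-yl in place of phenyl on an aromatic carbon. With both values shown being limits, no step between measured compounds exists, and nothing shown points to a change in either direction beyond the scatter; the change is expected to stay within the scatter, a step that the limit leaves unreadable from compound 2 to compound 3. Compound 3 is therefore expected to give about 15000 nM in this assay, within a range of 5000 nM to 50000 nM, and most probably again reported only as a limit.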

Compound 3, half-maximal effective concentration: > 1000 nM
Compound 3: no number, only a limit; the forecaster's own chance of this, stated with the estimate: 80%; the middle value is on the limit's open side.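

In this assay compound 3 gives only a limit, > 1000 nM. Compound 2 likewise gives only a limit, > 10000 nM, and no step can be read between these two compounds. The compounds shown leave open whether pyrrolidin-1-yl in place of phenyl changes the read-out at all.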